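Propyl in place of hydroxy: expectation for compound 4

The compounds below may be only part of what the source reports. "The series", "measured", "known", "first", "only" and "open" are said of these compounds alone.

Compound 3 `CCCc1cc(N)c2cc(NC(=O)/C=C/c3ccc(O)cc3)ccc2n1` gives 1100 nM in an assay on isolated protein for displacement of a labelled ligand from melanin-concentrating hormone receptor 1 (Homo sapiens) (on this read-out higher numbers stand for weaker inhibition and lower numbers for stronger inhibition), the highest of the three numbers in hand. Compound 1 `CCCc1cc(N)c2cc(NC(=O)/C=C/c3ccc(Cl)cc3)ccc2n1` gives 6 nM and compound 2 `CCc1cc(N)c2cc(NC(=O)/C=C/c3ccc(C(F)(F)F)cc3)ccc2n1` gives 1.2 nM in this assay. For the measured compounds named here, the only measured step at this position, a 180-fold higher number from compound 1 to compound 3 (2.26 log units; beyond the scatter), was large. Compound 4 `CCCc1ccc(/C=C/C(=O)Nc2ccc3nc(CCC)cc(N)c3c2)cc1` carries the change (propyl in place of hydroxy on an aromatic carbon); the propyl, like the chloro of compound 1, counts no hydrogen-bond donor or acceptor. Going by the values given here, no measured step covers propyl itself, so the expectation rests on undoing the loss seen in compound 1 because of a 180-fold higher number from compound 1 to compound 3 (2.26 log units; beyond the scatter). Compound 4 is therefore expected to give 8 nM (range 2 nM to 40 nM) in this assay, an expected step of a 140-fold lower number from compound 3 to compound 4 (2.14 log units; beyond the scatter).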

Compound 4, half-maximal inhibitory concentration: 4 nM
Compound 4: middle estimate off by 2.0-fold (0.30 log units), on the high side; measured number inside the range.
By their numbers in this assay, from the lowest: compound 2; then compounds 4 and 1 (each within the scatter of the next); then compound 3.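

In this assay, 4-propylphenyl in place of 4-hydroxyphenyl gives a 280-fold lower number from compound 3 to compound 4 (2.44 log units; beyond the scatter), so the loss seen with hydroxy is recovered by a group other than chloro. Propyl and chloro are not separated at this position, with a 1.5-fold lower number from compound 1 to compound 4 (0.18 log units; within the scatter), and this larger group with 0 hydrogen-bond donors and 0 hydrogen-bond acceptors is accommodated. No available evidence explains the effect of either change.

Going by these compounds, whether the loss with hydroxy follows its hydrogen-bond donor or its acceptor remains open, and a methoxy group or an amine here would bear on that. On these data alone, the length limit also remains open, which a butyl or longer chain would address.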